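Trimming the Phenyl: From Compound 2 to Compound 3

The source may report more compounds than this note shows. Statements on the series, on what has been measured and on what is new or still open speak of the compounds shown alone.

For the measured compounds named here, compound 2 `O[C@H]1[C@H](O)CN[C@@H]1c1ccc(-c2ccccc2)cc1` gives 2.9% in an assay on lysosomes for inhibition of Maltase-glucoamylase (Homo sapiens), read by spectrophotometry, tested at 1000 uM (a lower number here means less inhibition, a higher number more inhibition at the concentration tested (going by the name of the read-out)), the lowest of the two numbers so far; compound 1 `Cc1ccc([C@H]2NC[C@@H](O)[C@@H]2O)cc1` gives 15%. The change to compound 3 `O[C@H]1[C@H](O)CN[C@@H]1c1ccccc1` is hydrogen in place of phenyl on an aromatic carbon. Going by the values given here, the one measured step that bears on it is a number 12.1 percentage points lower from compound 1 to compound 2 (beyond the scatter), a structural change in the opposite sense, where adding a phenyl lowered inhibition. Removing that phenyl is therefore expected to bring a modest rise; the expected step is a number 7.1 percentage points higher from compound 2 to compound 3 (within the scatter). Compound 3 is estimated to give about 10%, with a range from 0% to 25%.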

Compound 3, a percentage reported as inhibition, at one concentration (the size of the read-out at that concentration, not a potency): 29%
Estimate against measurement, compound 3: 19 percentage points below; the whole stated range lies below it.
By their numbers in this assay, from the lowest: compound 2; then compound 1; then compound 3.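

With hydrogen on this aromatic carbon, the data show a number 26.1 percentage points higher from compound 2 to compound 3 (beyond the scatter), and also a number 14 percentage points higher from compound 1 to compound 3 (beyond the scatter). In this assay the three groups at this place therefore fall into one order, with hydrogen highest, then methyl, then phenyl, so even methyl already goes with less inhibition than hydrogen. Nothing available gives a reason for this order. Going by these compounds, whether a methoxy group, a chlorine atom or an amine on this carbon would fit the same order stays open. So does whether any group here could exceed hydrogen.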